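Fluoro to bromo next to the ring nitrogen

The source may hold more compounds than are shown below. What is called first, only, known or untested is meant among the compounds shown, and "the series" means these compounds.

Measured compounds:
compound 1 `CN1CCC[C@H]1COc1cc(Br)c[n+]([O-])c1` in an assay on membranes from brain for displacement of a labelled ligand from Neuronal acetylcholine receptor; alpha4/beta2 (Rattus norvegicus) (a higher number here means a weaker inhibitor, a lower number a stronger inhibitor), gives 34.8 nM;
compound 2 `CN1CCC[C@H]1COc1ccc(F)nc1` in this assay gives 2.56 nM.

Of the two numbers, compound 2 stands lowest; compound 1 is the only other point, and it lies beyond the scatter above it. Compound 3 `CN1CCC[C@H]1COc1ccc(Br)nc1` differs from compound 2 by bromo in place of fluoro on an aromatic carbon next to the ring nitrogen. Going by the values given here, no measured pair shows this exchange. The step is expected to stay within the scatter in either direction, a 1.4-fold higher number from compound 2 to compound 3 (0.14 log units; within the scatter). For compound 3 the expected inhibition constant is 3.5 nM, between 1 nM and 12 nM.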

Compound 3, inhibition constant: 1.91 nM
Compound 3: the middle estimate sits 1.8-fold (0.26 log units) above what was measured, within the range that was stated.
By their numbers in this assay, from the lowest: compounds 3 and 2 (each within the scatter of the next); then compound 1.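

In this assay, bromo in place of fluoro on an aromatic carbon next to the ring nitrogen gives a 1.3-fold lower number from compound 2 to compound 3 (0.13 log units; within the scatter) and so leaves the two halogens indistinguishable at this position. Going by these compounds alone, this is the only exchange at this position that can be read, and it shows that here the bromo and fluoro compounds stand together, with compound 1 apart from both. No evidence is available that would give a reason for this result.

From the compounds shown here alone, whether an amine, a methoxy group or a nitrile on this carbon would give a number close to those of compound 2 and compound 3 stays open.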